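Furyl pyrazoline series: aryl substituent swap, nitro to methoxy

The source may hold more compounds than are shown below. What is called first, only, known or untested is meant among the compounds shown, and "the series" means these compounds.

Two members of the series have numbers in a functional assay on OVCAR cells (Homo sapiens) for cytotoxicity, read by sulforhodamine B assay, with a stated time of 48 h (a lower number here means a stronger inhibitor, a higher number a weaker inhibitor), so far. Compound 1 `CC(=O)N1N=C(c2ccco2)CC1c1cccc(O)c1` carries a hydroxy on the pendant phenyl ring; in this assay compound 1 gives 13200 nM. Compound 2 `CC(=O)N1N=C(c2ccco2)CC1c1ccc([N+](=O)[O-])cc1` carries a nitro on that ring; in this assay compound 2 gives 23000 nM. Compound 2 has the higher of the two numbers, but the two values lie within the scatter of each other, so no order between compound 1 and compound 2 can be read from them. Both sit in the weak range.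

Compound 3 `COc1ccc(C2CC(c3ccco3)=NN2C(C)=O)cc1` differs from compound 2 in one place: methoxy in place of nitro on an aromatic carbon. Within the data shown here, no measured pair shows the size of this kind of change. Since both compound 1 and compound 2 give numbers in the same weak band whatever the substituent on the phenyl ring, the step of a 1.4-fold lower number from compound 2 to compound 3 (0.13 log units; within the scatter) is expected to be small, with no clear direction beyond the scatter. Compound 3 is therefore estimated at 17000 nM, with a plausible range from 7000 nM to 40000 nM.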

Compound 3, half-maximal inhibitory concentration: 14300 nM
Estimate against measurement, compound 3: 1.2-fold (0.08 log units) above; the range from low to high includes it.
By their numbers in this assay, from the lowest: compounds 1, 3 and 2 (each within the scatter of the next).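

In this assay, methoxy in place of nitro on an aromatic carbon, para to a large group, gives a 1.6-fold lower number from compound 2 to compound 3 (0.21 log units; within the scatter), the first step read at this position. The exchange removes a double bond outside aromatic rings and replaces a nitrogen-bearing group with a carbon-bearing one, yet the two compounds cannot be told apart in this assay, so this particular change at this position has no effect that can be resolved from the scatter. Nothing available explains this result or links it to any property of either group.

Going by these compounds, two groups at one position cover only a small part of what could sit there, and it remains open whether an amine, a carboxylic acid or a longer chain such as butoxy at the same aromatic carbon would shift the number beyond the scatter. On these data alone, it also remains open whether methoxy and nitro would stay indistinguishable at another place on the pendant phenyl ring, or with a different group on the shared core.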